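The compounds below may be only part of what the source reports. "The series", "measured", "known", "first", "only" and "open" are said of these compounds alone.

Measured so far in a functional assay on D4 cells (Cricetulus griseus) for inhibition, read by CellTiter-Blue, with a stated time of 96 h; on this read-out lower numbers stand for stronger inhibition and higher numbers for weaker inhibition
compound 1 `Nc1nc2[nH]c(CCCCCCCCC(=O)N[C@@H](CCC(=O)O)C(=O)O)cc2c(=O)[nH]1` gives 3.99 nM
compound 2 `Nc1nc2[nH]c(CCCCCCC(=O)O)cc2c(=O)[nH]1` gives > 1000 nM (a limit of the assay)
compound 3 `Nc1nc2[nH]c(CCCCCCCC(=O)O)cc2c(=O)[nH]1` gives > 1000 nM (a limit of the assay)

Compound 3 therefore has no exact number, only the limit > 1000 nM in this assay as its standing. Compound 4 `Nc1nc2[nH]c(CCCCCCCCC(=O)O)cc2c(=O)[nH]1` differs from it by one change: carboxymethyl in place of carboxy on a saturated chain carbon, seven bonds along the chain from an aromatic carbon.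

Going by the values given here, the only measured step of this kind is a step that the two limits leave unreadable from compound 2 to compound 3 and it gives no size to carry forward. Both compounds ending in a free carboxy group sit at the limit of > 1000 nM in this assay, at which 2 of the 3 values shown sit, and neither has crossed it. Compound 1 ends its chain in an amide instead, and it alone gives a number, 3.99 nM in this assay. Compound 4 keeps the free carboxy end, so no clear gain is expected from the added chain carbon. The expected change is a step that the limit leaves unreadable from compound 3 to compound 4 and this is only an estimate. For compound 4 the estimated value is 1500 nM with an expected range from 300 nM to 5000 nM and a report of only a limit is the likeliest outcome.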

Compound 4, half-maximal inhibitory concentration: > 1000 nM
Compound 4: no number, only a limit; the forecaster's own chance of this, stated with the estimate: 85%; the middle value does not contradict the limit.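

Adding one more chain carbon to the free carboxy end, carboxymethyl in place of carboxy, still does not bring this series off the limit in this assay: the limit of > 1000 nM in this assay, at which 3 of the 4 values shown sit.

The steps among compound 2, compound 3 and compound 4 cannot be read, so no size can be given for the effect of chain length. Compound 4 does supply a one-place comparison with the amide, and hydroxy in place of (1,3-dicarboxypropyl)amino on a carbonyl carbon gives an at least 250-fold higher number from compound 1 to compound 4 (2.39 log units; beyond the scatter).

Going by these compounds, it remains open whether a longer chain ending in a carboxylic acid would ever give a number in this assay. Also open, on these data alone, is whether a simple amine in place of (1,3-dicarboxypropyl)amino, forming a plainer amide, would stay close to compound 1 at 3.99 nM.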